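The source may report more compounds than this note shows. Statements on the series, on what has been measured and on what is new or still open speak of the compounds shown alone.

Measured so far in an ADME assay on MT2 cells (Homo sapiens) for cytotoxicity, read by MTT assay; on this read-out lower numbers stand for higher toxicity in this test and higher numbers for lower toxicity in this test:
Compound 1, `Fc1cccc(F)c1Cc1cnc(Nc2ccc(Oc3ccncc3)c(Cl)c2)o1`, gives 21000 nM.
Compound 2, `O=c1ncccn1SCCc1ccc(Nc2ncc(Cc3c(F)cccc3F)o2)cc1`, gives > 100000 nM.
Compound 3, `COCc1ccc(Nc2nnc(Cc3c(Cl)cccc3Cl)o2)cc1`, gives 100000 nM.

The value for compound 2 is a limit of the test and not a number. Compound 2 therefore sits at the limit of > 100000 nM in this assay, at which 1 of the 3 values shown sits, so the numbers show only that its toxicity in this assay lies beyond what the test reports.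

Compound 4, `OCCc1ccc(Nc2ncc(Cc3c(F)cccc3F)o2)cc1`, has not yet been measured. Set against compound 2, it differs by one oxygen atom in place of a group of 8 heavy atoms (4 carbon, 2 nitrogen, 1 oxygen, 1 sulfur; one six-membered aromatic ring with 2 hetero atoms), on a saturated chain carbon, two bonds along the chain from an aromatic carbon.

No measured step between the compounds shown involves this change, so the expectation rests on the starting point alone. The expected step of an at least 1.2-fold lower number from compound 2 to compound 4 (0.09 log units; that floor lies within the scatter) is none beyond the usual scatter. Compound 4 is expected at 80000 nM, within 30000 nM to 150000 nM.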

Compound 4, half-maximal cytotoxic concentration: 35000 nM
The estimate for compound 4 lay 2.3-fold (0.36 log units) above the measured number; the measured number falls inside the stated range.
By their numbers in this assay, from the lowest: compounds 1 and 4 (each within the scatter of the next); then compound 3.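

In this assay, going by these compounds alone, putting hydroxy in place of the group that leaves, on the saturated chain carbon, gives an at least 2.8-fold lower number from compound 2 to compound 4 (0.45 log units; beyond the scatter) and is the first single change seen here, so this position does bear on the read-out. The full size of the step stays unknown, since the value for compound 2 is a limit of the test and not a number: the limit of > 100000 nM in this assay, at which 1 of the 4 values shown sits.

The compounds shown do not tell whether the hydroxy itself matters or only the loss of the larger group. They also do not tell how an amine, a carboxylic acid or a methoxy at this place would read.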